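Phenyl to pyridin-2-yl in compound 2

The source may hold more compounds than are shown below. What is called first, only, known or untested is meant among the compounds shown, and "the series" means these compounds.

Values in an ADME assay on Vero cells (Chlorocebus sabaeus) for cytotoxicity, read by MTT assay (on this read-out lower numbers stand for stronger inhibition and higher numbers for weaker inhibition), so far
Compound 1 `C=CCOc1cc(OC)c(C(=O)/C=C/c2ccc(O)cc2)c(OCC=C)c1` gives 76400 nM
Compound 2 `C=CCOc1cc(OC)c(C(=O)/C=C/c2ccccc2)c(OCC=C)c1` gives 17100 nM
Compound 3 `COc1ccc(/C=C/C(=O)c2c(O)cc(O)cc2OC)cc1` is recorded as "not determined" (no result reported)

Compound 2 holds the lower of the two numbers (17100 nM), with compound 1 above it. Compound 4 `C=CCOc1cc(OC)c(C(=O)/C=C/c2ccccn2)c(OCC=C)c1` differs from compound 2 by pyridin-2-yl in place of phenyl on a double-bonded chain carbon bound to a double-bonded chain carbon. Going by the values given here, the only measured step is a 4.5-fold lower number from compound 1 to compound 2 (0.65 log units; beyond the scatter), with hydrogen in place of hydroxy on an aromatic carbon. That is a different change, so it offers only a rough scale. A smaller step, leaning toward a higher number, is expected in this assay, namely a 1.5-fold higher number from compound 2 to compound 4 (0.18 log units; within the scatter). For compound 4 the estimated value is 26000 nM (range 8000 nM to 70000 nM).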

Compound 4, half-maximal inhibitory concentration: 2800 nM
Beside the measured number, compound 4's estimate is 9.3-fold (0.97 log units) above it; the measured number lies below the stated range.
By their numbers in this assay, from the lowest: compound 4; then compound 2; then compound 1.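

In this assay, going by these compounds alone, the aromatic ring on this double-bonded chain carbon responds to a change within the ring itself, not only to a group carried on it: pyridin-2-yl in place of phenyl gives a 6.1-fold lower number from compound 2 to compound 4 (0.79 log units; beyond the scatter) and pyridin-2-yl in place of 4-hydroxyphenyl gives a 27-fold lower number from compound 1 to compound 4 (1.44 log units; beyond the scatter) as the largest step so far. Nothing available here accounts for this change in the number. The compounds shown leave open whether pyridin-3-yl or pyridin-4-yl would give a similar number, and what an amine or a carboxylic acid on the pyridin-2-yl ring would do.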